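A few compounds are considered here, and "the series" means these few. Any claim that something is new, unique, unknown or untested is made for them only; others in the source may bear on it.

Within the data shown here, in a functional assay on HCT-116 cells (Homo sapiens) for antiproliferative activity, read by MTT assay, with a stated time of 48 h (a higher number here means a weaker inhibitor, a lower number a stronger inhibitor), compound 1 `COc1ccc(-c2cc3c(cn2)[nH]c(=O)n3-c2cc(OC)c(OC)c(OC)c2)cc1F` gives 910 nM, the lower of the two numbers measured so far. Compound 2 `COc1ccc(-c2cc3c(cn2)[nH]c(=O)n3-c2cc(OC)c(OC)c(OC)c2)cc1C(=O)O`, with carboxy in place of fluoro on an aromatic carbon, gives 3070 nM. Among the measured compounds shown here, this is the only measured step, a 3.4-fold higher number from compound 1 to compound 2 (0.53 log units; beyond the scatter), and it is modest. Compound 3 `COc1ccc(-c2cc3c([nH]c(=O)n3-c3cc(OC)c(OC)c(OC)c3)c(C(N)=O)n2)cc1F` retains the 3-fluoro-4-methoxyphenyl group of compound 1 and is altered on the shared core instead: carbamoyl in place of hydrogen on an aromatic carbon. For the measured compounds named here, the carbamoyl sits on an aromatic carbon next to the ring nitrogen, a place where neither measured compound carries a new group, so the one measured step is only a loose guide. Taking a 3.4-fold higher number from compound 1 to compound 2 (0.53 log units; beyond the scatter) as that guide, the expected step is similarly modest and upward, a 1.6-fold higher number from compound 1 to compound 3 (0.22 log units; within the scatter), although a change within the scatter would not be surprising. The estimate in this assay for compound 3 is 1500 nM, with an expected range of 400 nM to 6000 nM.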

Compound 3, half-maximal inhibitory concentration: 360 nM
For compound 3 the middle estimate is 4.2-fold (0.62 log units) above the measured one; the measured number lies below the stated range.
By their numbers in this assay, from the lowest: compound 3; then compound 1; then compound 2.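

In this assay, the shared core accepts a new group on the aromatic carbon next to the ring nitrogen: placing carbamoyl there gives a 2.5-fold lower number from compound 1 to compound 3 (0.40 log units; beyond the scatter). This change on the core moves the number in the opposite direction from the change on the phenyl ring, which gives a 3.4-fold higher number from compound 1 to compound 2 (0.53 log units; beyond the scatter), so a substituent on this carbon can strengthen the compound rather than weaken it. No measurement shown here explains why the number falls.

From the compounds shown here alone, it remains open whether this gain is specific to carbamoyl or would also appear with a smaller group such as a nitrile, a charged one such as a carboxylic acid, or an amine at the same carbon. Going by these compounds, it is also open whether carbamoyl has the same effect when the carboxy group of compound 2 replaces the fluoro group.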